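This account rests on a few compounds, and the source may have more. Where it says the series, first, only, none or still open, it means among the compounds named here.

Measured so far in a functional assay on A549 cells (Homo sapiens) for inhibition, read by sulforhodamine B assay, with a stated time of 48 h; on this read-out higher numbers stand for weaker inhibition and lower numbers for stronger inhibition:

Compound 1 `CCOC(=O)CO/N=C(/c1ccc(OC)c(OC)c1OC)c1cccc2ccccc12` gives 6720 nM
Compound 2 `COc1ccc(C(OCc2ccccc2)c2cccc3ccccc23)c(OC)c1OC` gives 13500 nM
Compound 3 `COc1ccc(/C(=C/c2ccc(F)cc2)c2cccc3ccccc23)c(OC)c1OC` gives 18600 nM

Compound 2, at 13500 nM in this assay, lies within the usual scatter of both compound 1 and compound 3, so it cannot be told apart from either one.

Compound 4 `C=CCOC(c1ccc(OC)c(OC)c1OC)c1cccc2ccccc12` has not yet been measured. Its difference from compound 2 is vinyl in place of phenyl on a saturated chain carbon bound to an oxygen on a saturated carbon, which turns benzyloxy into allyloxy. Going by the values given here, no measured pair of compounds shows a change of this kind, so the data offer no direction for it. In this assay the expectation is therefore no step beyond the scatter, and it rests on compound 2 at 13500 nM as the nearest measured structure. The estimated 1.0-fold lower number from compound 2 to compound 4 (0.02 log units; within the scatter) stays within that scatter. For compound 4 the estimated value is 13000 nM (expected range 5500 nM to 30000 nM).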

Compound 4, half-maximal inhibitory concentration: 9710 nM
Compound 4: middle estimate off by 1.3-fold (0.13 log units), on the high side, and the stated range covers the measured number.
By their numbers in this assay, from the lowest: compounds 1, 4, 2 and 3 (each within the scatter of the next, the first and the last beyond it).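

Replacing benzyloxy with allyloxy gives a 1.4-fold lower number from compound 2 to compound 4 (0.14 log units; within the scatter) in this assay and so stays within the usual scatter. Going by these compounds alone, this is the first pair here that differs in one place, and it shows that on a saturated chain carbon bound to an oxygen on a saturated carbon, vinyl can stand in place of phenyl without a change this read-out can separate from repeat scatter, so for this pair the six-membered aromatic ring is not needed to keep the number. Nothing else measured on these compounds bears on this result.

From the compounds shown here alone, whether a different kind of group in the same place, such as an amine, a carboxylic acid or a longer chain, would move the number remains open. Compound 1 and compound 3 still have no partner that differs from them in one place, so what sets them apart cannot be read.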